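Replacing a carbamate with an ester on the ring

This account rests on a few compounds, and the source may have more. Where it says the series, first, only, none or still open, it means among the compounds named here.

Measured compounds:
- compound 1 `CC(C)(C)OC(=O)NC1CCN(C(=O)CN2CN(c3ccccc3)C3(CCN(C(=O)c4ccc(C(C)(C)C)cc4)CC3)C2=O)CC1`: 8300 nM
- compound 2 `CC(C)(C)OC(=O)NC1CCN(C(=O)CN2CN(c3ccccc3)C3(CCN(C(=O)c4ccc(C5CCCCC5)cc4)CC3)C2=O)CC1`: 4800 nM
- compound 3 `CC(C)(C)OC(=O)N1CCN(C(=O)CN2CN(c3ccccc3)C3(CCN(C(=O)c4ccc(C5CCCCC5)cc4)CC3)C2=O)CC1`: 3500 nM

All three numbers come from an assay on HEK293 cells for displacement of a labelled ligand from NPC1-like intracellular cholesterol transporter 1 (Homo sapiens); on this read-out lower numbers stand for stronger inhibition and higher numbers for weaker inhibition. Compound 1 stands highest of the three, with compound 2 nearest and compound 3 furthest; the step of a 1.7-fold lower number from compound 1 to compound 2 (0.24 log units; within the scatter) lies within the scatter, while compound 3 lies beyond it. Compound 4 `CCOC(=O)C1CCN(C(=O)CN2CN(c3ccccc3)C3(CCN(C(=O)c4ccc(C(C)(C)C)cc4)CC3)C2=O)CC1` differs from compound 1 by ethoxycarbonyl in place of (tert-butoxycarbonyl)amino on a saturated ring carbon. Within the data shown here, no measured step touches this position, since the one known step concerns the aromatic carbon only, so no direction can be read from the data. The expected step of a 1.0-fold lower number from compound 1 to compound 4 (0.02 log units; within the scatter) is therefore none beyond the scatter. Compound 4 is estimated at 8000 nM in this assay, within a range of 3000 nM to 22000 nM.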

Compound 4, half-maximal inhibitory concentration: 3100 nM
For compound 4 the middle estimate is 2.6-fold (0.41 log units) above the measured one; the measured number falls inside the stated range.
By their numbers in this assay, from the lowest: compounds 4, 3, 2 and 1 (each within the scatter of the next, the first and the last beyond it).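

In this assay, ethoxycarbonyl in place of (tert-butoxycarbonyl)amino on the saturated ring carbon gives a 2.7-fold lower number from compound 1 to compound 4 (0.43 log units; beyond the scatter) and so shows that the group at this position can move the number, which the earlier step on the aromatic carbon could not show. The entering group has no hydrogen-bond donor and fewer heavy atoms, and these two differences arrive together here. Nothing available explains the shift. On these data alone, how a carboxylic acid or a primary amine on this carbon would compare remains open. So does whether the same swap holds with cyclohexyl on the aromatic carbon.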